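Swapping the aromatic group on compound 3

This account rests on a few compounds, and the source may have more. Where it says the series, first, only, none or still open, it means among the compounds named here.

Of the compounds shown here, three sharing one core have been tested in a functional assay on Shh Light II cells (Mus musculus) for inhibition, read by a luciferase reporter; on this read-out lower numbers stand for stronger inhibition and higher numbers for weaker inhibition. Compound 1 (`O=C(OC1CCCCC1)N1CCC(c2nc(-c3ccc4ccccc4n3)no2)CC1`) gives 580 nM, compound 2 (`CC(=O)N1CCC(NC(=O)N2CCC(c3nc(-c4ccc5ccccc5n4)no3)CC2)CC1`) gives 500 nM, and compound 3 (`O=C(Nc1ncccc1Cl)N1CCC(c2nc(-c3ccc4ccccc4n3)no2)CC1`) gives 2800 nM, the highest number of the three and so the weakest inhibitor here. Compound 4 (`Cc1ccccc1NC(=O)N1CCC(c2nc(-c3ccc4ccccc4n3)no2)CC1`) differs from compound 3 in one place: 2-methylphenyl in place of 3-chloropyridin-2-yl on an amide-type nitrogen.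

Two measured steps arrive at the group now being replaced: a 4.8-fold higher number from compound 1 to compound 3 (0.68 log units; beyond the scatter), and a 5.6-fold higher number from compound 2 to compound 3 (0.75 log units; beyond the scatter). Both are modest. The remaining measured step shows a 1.2-fold lower number from compound 1 to compound 2 (0.06 log units; within the scatter). Going by the values given here, no measured step compares two aromatic groups at this place, so the direction of the new step is poorly supported. Among the compounds with values here, compound 3 is the only measured compound with an aromatic ring here, which makes its 2800 nM the best starting point. A small change is therefore expected, with a 1.6-fold lower number from compound 3 to compound 4 (0.19 log units; within the scatter) as the estimated step. For compound 4 the estimated value is 1800 nM, with an expected range from 500 nM to 6000 nM.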

Compound 4, half-maximal inhibitory concentration: 440 nM
Compound 4: middle estimate off by 4.1-fold (0.61 log units), on the high side; measured number outside the range, below it.
By their numbers in this assay, from the lowest: compounds 4, 2 and 1 (each within the scatter of the next); then compound 3.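

In this assay, replacing 3-chloropyridin-2-yl with 2-methylphenyl on the amide-type nitrogen gives a 6.4-fold lower number from compound 3 to compound 4 (0.80 log units; beyond the scatter) and so shows that an aromatic ring at this place need not carry the weak number of compound 3. The other two new comparisons, a 1.1-fold lower number from compound 2 to compound 4 (0.06 log units; within the scatter) and a 1.3-fold lower number from compound 1 to compound 4 (0.12 log units; within the scatter), both lie within the scatter, so compound 4 stands level with compound 1 and compound 2 despite their very different groups, leaving compound 3 alone apart from them. Nothing measured here explains this step.

The swap removes the ring nitrogen and the chlorine and adds a methyl group all at once, so which of these changes accounts for the step remains open. A plain phenyl group on the same nitrogen would help to separate them.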